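Azaphilone epimer at the side-chain stereocentre: expected potency

A few compounds are considered here, and "the series" means these few. Any claim that something is new, unique, unknown or untested is made for them only; others in the source may bear on it.

Compound 1: `C/C=C(\Cl)C(=O)[C@@](C)(O)[C@H]1CC(=O)C(C)=C2C=C(/C=C/[C@@H](C)[C@@H](C)O)OC=C21` gives 0.0012 nM in a functional assay on HL-60 cells (Homo sapiens) for cytotoxicity, read by MTT assay, with a stated time of 72 h; a lower number here means a stronger inhibitor, a higher number a weaker inhibitor.
Compound 2: `C/C=C(\C)C(=O)C[C@H]1C2=COC(/C=C/[C@H](C)[C@@H](C)O)=CC2=C(Cl)C(=O)[C@@]1(C)O` gives 0.001 nM in this assay.

Compound 2 holds the lower of the two numbers, but its gap to compound 1 is within the scatter, so the two are indistinguishable. Going by the values given here, compound 3, `C/C=C(\C)C(=O)C[C@H]1C2=COC(/C=C/[C@@H](C)[C@@H](C)O)=CC2=C(Cl)C(=O)[C@@]1(C)O`, is untested. the two compounds have the same atoms and bonds and differ only in configuration as drawn: 1 of 6 stereo elements differ; a stereocentre at a saturated chain carbon is drawn S in compound 2 and R in compound 3 With no measured pair showing this change, the step is expected to be no larger than the scatter, in either direction. Compound 3 is estimated at 0.0012 nM, within 0.0004 nM to 0.004 nM. The change this estimate implies from compound 2 to compound 3 is a 1.2-fold higher number from compound 2 to compound 3 (0.08 log units; within the scatter), expected to stay within the scatter.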

Compound 3, half-maximal inhibitory concentration: 0.0011 nM
Beside the measured number, compound 3's estimate is 1.1-fold (0.04 log units) above it; the range from low to high includes it.
By their numbers in this assay, from the lowest: compounds 2, 3 and 1 (each within the scatter of the next).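

In this assay, going by these compounds alone, inverting the saturated chain carbon gives a 1.1-fold higher number from compound 2 to compound 3 (0.04 log units; within the scatter) and so provides the first measured pair for this stereocentre. With the rest of compound 2 held fixed, the S and R drawings at this carbon cannot be told apart in this read-out. The comparison isolates this one stereocentre: the fact that compounds 2 and 3 differ only in the configuration as drawn

From the compounds shown here alone, whether the other stereo elements behave the same way remains open. So does the effect of placing an amine or a carboxylic acid where the side-chain hydroxyl stands.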